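The source may report more compounds than this note shows. Statements on the series, on what has been measured and on what is new or still open speak of the compounds shown alone.

Measured so far:
- compound 1, `Cc1nc2c3ccccc3ccc2c2nc3c(ccc4ccccc43)c(-c3ccccc3Cl)c12`: 118 ug/mL
- compound 2, `Cc1nc2c3ccccc3ccc2c2nc3c(ccc4ccccc43)c(-c3cccc([N+](=O)[O-])c3)c12`: 117 ug/mL

Working notes. Two numbers exist in a functional assay, read by spectrophotometry, with a stated time of 30 min; a lower number here means a stronger inhibitor, a higher number a weaker inhibitor. Compound 1 gives 118 ug/mL, and compound 2 gives 117 ug/mL; the two lie within the scatter of each other, a 1.0-fold lower number from compound 1 to compound 2 (0.00 log units; within the scatter), so neither can be placed apart from the other on these numbers.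

Compound 3, `Cc1nc2c3ccccc3ccc2c2nc3c(ccc4ccccc43)c(-c3ccccc3)c12`, is not yet measured. Against compound 1 the difference is hydrogen in place of chloro on an aromatic carbon. Among the measured compounds shown here, no measured step removes a chloro on its own; the one step known, a 1.0-fold lower number from compound 1 to compound 2 (0.00 log units; within the scatter), exchanges the whole aryl group and leaves the number unchanged. For the measured compounds named here, that is the only bearing evidence, and it points to a flat series at this position. The expectation for compound 3 is therefore no step beyond the scatter, a 1.0-fold higher number from compound 1 to compound 3 (0.01 log units; within the scatter). Compound 3 is estimated at 120 ug/mL, with a range from 60 ug/mL to 240 ug/mL.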

Compound 3, half-maximal inhibitory concentration: 164 ug/mL
The estimate for compound 3 lay 1.4-fold (0.14 log units) below the measured number, within the range that was stated.
By their numbers in this assay, from the lowest: compounds 2, 1 and 3 (each within the scatter of the next).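

In this assay, among the compounds shown here, compound 3 gives the first reading at this position with no substituent on the phenyl: hydrogen in place of chloro is a 1.4-fold higher number from compound 1 to compound 3 (0.14 log units; within the scatter), and hydrogen in place of nitro is a 1.4-fold higher number from compound 2 to compound 3 (0.15 log units; within the scatter). Neither the 2-chlorophenyl of compound 1 nor the 3-nitrophenyl of compound 2 can therefore be set apart from the plain phenyl of compound 3, so neither substituent is shown to make a difference here. Nothing measured on these compounds speaks to the reason for this flat reading.

From the compounds shown here alone, all three compounds carry a phenyl at this place, bearing only chloro, nitro or hydrogen, so how an amine, a carboxylic acid or a longer chain would read there remains open. Going by these compounds, whether any change at this position gives a step beyond the scatter also remains open.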